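Swapping the aryl group on the triazole nitrogen

A few compounds are considered here, and "the series" means these few. Any claim that something is new, unique, unknown or untested is made for them only; others in the source may bear on it.

Among the measured compounds shown here, compound 2 `COc1ccccc1-n1nncc1CN1C(=O)C2(C(C#N)=C(N)Oc3c(N)cc4nc5ccccc5nc4c32)c2ccccc21` is the only compound with a number in a functional assay on MCF7 cells (Homo sapiens) for antiproliferative activity, read by MTT assay, with a stated time of 48 h (on this read-out higher numbers stand for weaker inhibition and lower numbers for stronger inhibition), where compound 2 gives 28900 nM. Compound 1 `COc1ccc(-n2nncc2CN2C(=O)C3(C(C#N)=C(N)Oc4c3c3nc5ccccc5nc3c3ccccc43)c3ccccc32)cc1` reaches only a limit of the assay, as compound 1 gives > 50000 nM in this assay, consistent with the limit of > 50000 nM in this assay, at which 1 of the 2 values shown sits. Compound 3 `N#CC1=C(N)Oc2c(N)cc3nc4ccccc4nc3c2C12C(=O)N(Cc1cnnn1-c1ccc([N+](=O)[O-])cc1[N+](=O)[O-])c1ccccc12` differs from compound 2 by 2,4-dinitrophenyl in place of 2-methoxyphenyl on an aromatic nitrogen. For the measured compounds named here, no measured step of a single change is known here, so the step is expected to stay within the scatter: compound 3 is expected to give 30000 nM in this assay, between 10000 nM and 90000 nM, a step of a 1.0-fold higher number from compound 2 to compound 3 (0.02 log units; within the scatter).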

Compound 3, half-maximal inhibitory concentration: 20900 nM
For compound 3 the middle estimate is 1.4-fold (0.16 log units) above the measured one; measured number inside the range.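

In this assay, putting 2,4-dinitrophenyl in place of 2-methoxyphenyl on this aromatic nitrogen gives a 1.4-fold lower number from compound 2 to compound 3 (0.14 log units; within the scatter), so the two aryl groups cannot be told apart on this read-out. The position therefore accepts an aryl group with more heavy atoms and more hydrogen-bond acceptors without the number leaving the scatter. Nothing measured here bears on why the two groups read alike.

As far as these compounds go, it remains open whether a plain alkyl chain in place of the ring, or an aryl ring carrying an amine or a carboxylic acid, would move the number beyond the scatter. The compounds shown also do not separate the contributions of the two nitro groups.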